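Phenyl to Methyl on an Aromatic Nitrogen: Expected Loss

The source may hold more compounds than are shown below. What is called first, only, known or untested is meant among the compounds shown, and "the series" means these compounds.

Compound 1 `COC1Cc2c(cnn2-c2ccccc2)C2(CCN(CCCc3ccccc3)CC2)O1` and compound 2 `COC1Cc2c(cnn2C)C2(CCN(CCCc3ccccc3)CC2)O1` differ in one place: methyl in place of phenyl on an aromatic nitrogen. In an assay for displacement of a labelled ligand from Sigma non-opioid intracellular receptor 1 (Cavia porcellus), read by scintillation counting, with a stated time of 180 min (on this read-out lower numbers stand for stronger inhibition and higher numbers for weaker inhibition), compound 1 gives 3.2 nM, and compound 2 gives 93 nM; the step is a 29-fold higher number from compound 1 to compound 2 (1.46 log units; beyond the scatter). Compound 3 `c1ccc(CN2CCC3(CC2)OCCc2c3cnn2-c2ccccc2)cc1` gives 1.71 nM in this assay. How the core of compound 3 differs from that of compound 1 is not broken down here. Compound 4 `Cn1ncc2c1CCOC21CCN(Cc2ccccc2)CC1` has not yet been measured in this assay; it differs from compound 3 by methyl in place of phenyl on an aromatic nitrogen, the same kind of change as that from compound 1 to compound 2, with its place described in the same words. Because a 29-fold higher number from compound 1 to compound 2 (1.46 log units; beyond the scatter) was large, a step of similar size is expected here, a 29-fold higher number from compound 3 to compound 4 (1.47 log units; beyond the scatter). Compound 4 is therefore estimated at 50 nM, with a likely range from 15 nM to 160 nM.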

Compound 4, inhibition constant: 9.2 nM
Compound 4: the middle estimate sits 5.4-fold (0.74 log units) above what was measured, and the stated range ends above it.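

Replacing phenyl with methyl on the aromatic nitrogen weakens binding on the second core too, with a 5.4-fold higher number from compound 3 to compound 4 (0.73 log units; beyond the scatter) in this assay. These two pairs show only that the direction of the change carried over, and they cannot tell which feature of the cores sets the size of the step or predict that size on a third core. The size itself did not carry over from one core to the other: the same change on two cores in this assay, a 29-fold higher number (1.46 log units; beyond the scatter) from compound 1 to compound 2 and a 5.4-fold higher number (0.73 log units; beyond the scatter) from compound 3 to compound 4, 5.4-fold (0.73 log units) apart, beyond the scatter of two such steps

The compounds shown leave open how other groups on that nitrogen would behave, such as ethyl, benzyl or a longer carbon chain. They also leave open whether a fluorine on the phenyl ring would change the result.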